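Swapping a fluorophenyl for a branched alkyl at the chain carbon

The compounds below may be only part of what the source reports. "The series", "measured", "known", "first", "only" and "open" are said of these compounds alone.

Measured compounds:
compound 1, `Fc1cccc(F)c1Cn1c(-c2c(F)cccc2F)nc2ccncc21`, 99000 nM
compound 2, `Fc1ccccc1Cn1ccc2nc(-c3ccccc3)nc-2c1`, > 100000 nM
compound 3, `c1ccc(CCCCn2ccc3nc(-c4ccccc4)nc-3c2)cc1`, 95000 nM

Of the compounds shown here, three have been tested in an ADME assay on MDBK cells (Bos taurus) for cytotoxicity; a higher number here means that more compound is tolerated, a lower number that less compound is tolerated. Compound 1 gives 99000 nM and compound 3 gives 95000 nM, two values that lie within the scatter of one another. For compound 2 the assay reports only a limit, > 100000 nM, so no number is known for it; compound 2 sits at the limit of > 100000 nM in this assay, at which 1 of the 3 values shown sits, and its true value can only be said to be that high or higher.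

Compound 4, `CCC(CC)Cn1ccc2nc(-c3ccccc3)nc-2c1`, has not yet been measured. It differs from compound 2 in one place: pentan-3-yl in place of 2-fluorophenyl on a saturated chain carbon bound to an aromatic nitrogen. Going by the values given here, nothing among the measured compounds shows what this particular exchange does, and no step between measured compounds is available to anchor it. All three measured compounds sit close to the top of the range of this assay, and compound 4 is expected to do the same, with a step from compound 2 of a number no higher from compound 2 to compound 4 (the limit leaves the size open) that is expected to be none beyond the scatter. Compound 4 is therefore estimated at 100000 nM, with a range from 50000 nM to 200000 nM, and a fair chance that this assay again reports only a limit.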

Compound 4, half-maximal cytotoxic concentration: > 100000 nM
Compound 4: only a limit was reported; the forecaster's own chance of this, stated with the estimate: 50%; the middle value sits exactly at the limit.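

Compound 2 and compound 4 both carry only a limit in this assay, so the step between them cannot be read: the limit of > 100000 nM in this assay, at which 2 of the 4 values shown sit.

The compounds shown leave open how far either true value lies past that limit, and whether pentan-3-yl in place of 2-fluorophenyl changes tolerance at all.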